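A Fluorophenyl Swap on the Shared Core

This account rests on a few compounds, and the source may have more. Where it says the series, first, only, none or still open, it means among the compounds named here.

In a functional assay on PC-12 cells (Rattus norvegicus) for cytotoxicity, read by MTT assay, with stated times of 2 h and 24 h, tested at 1 uM (a lower number here means a weaker effect, a higher number a stronger effect of the compound at the concentration tested), compound 1 `Oc1cc(C(F)(F)F)ccc1-c1nc(-c2ccccc2O)n(-c2ccc(Cl)cc2)n1` gives 68%, the second highest of three numbers. Compound 2 `COc1ccc(-n2nc(-c3ccc(C(F)(F)F)cc3O)nc2-c2ccccc2O)cc1` gives 69%, and compound 3 `N#Cc1ccc(-n2nc(-c3ccc(C(F)(F)F)cc3O)nc2-c2ccccc2O)cc1` gives 66.6%. The steps among them are small: a number 1 percentage points higher from compound 1 to compound 2 (within the scatter), a number 1.4 percentage points lower from compound 1 to compound 3 (within the scatter) and a number 2.4 percentage points lower from compound 2 to compound 3 (within the scatter), each within the scatter. Compound 4 `Oc1cc(C(F)(F)F)ccc1-c1nc(-c2ccccc2O)n(-c2cccc(F)c2)n1` differs from compound 1 by 3-fluorophenyl in place of 4-chlorophenyl on an aromatic nitrogen. For the measured compounds named here, the measured steps each exchange one group on an aromatic carbon and none moved this assay beyond the scatter; no measured step exchanges a whole aryl group on the aromatic nitrogen, so they bear on the new change only loosely. A step no larger than the scatter is therefore expected. Compound 4 is estimated at 68%, between 58% and 78%, which is expected to mean no change at the digits printed from compound 1 to compound 4 (within the scatter).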

Compound 4, a percentage reported as activity, at one concentration (the size of the read-out at that concentration, not a potency): 67.2%
Beside the measured number, compound 4's estimate is 0.8 percentage points above it; low and high end bracket the measured number.
By their numbers in this assay, from the lowest: compounds 3, 4, 1 and 2 (each within the scatter of the next).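

Exchanging a whole aryl group on the aromatic nitrogen leaves this assay within the scatter (a number 0.8 percentage points lower from compound 1 to compound 4 (within the scatter)). The same holds against the other two aryl groups (a number 0.6 percentage points higher from compound 3 to compound 4 (within the scatter)) and (a number 1.8 percentage points lower from compound 2 to compound 4 (within the scatter)), so 3-fluorophenyl cannot be told apart from 4-chlorophenyl, 4-cyanophenyl or 4-methoxyphenyl here at this one concentration. No supporting measurement bears on why these numbers sit so close. Still open, on these data alone, is whether a phenyl carrying an amine or a carboxylic acid, or a plain alkyl chain replacing the aryl group, would shift the number.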